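This account rests on a few compounds, and the source may have more. Where it says the series, first, only, none or still open, it means among the compounds named here.

Measured compounds:
compound 1, `COc1ccccc1/C=c1\c(=O)[nH]/c(=C/c2cccc(Cl)c2Cl)c(=O)n1C`, 100 nM
compound 2, `C=CCn1c(=O)/c(=C\c2cc(F)ccc2C)[nH]c(=O)/c1=C\c1ccccc1OC`, 1000 nM
compound 3, `COc1ccccc1/C=c1\c(=O)[nH]/c(=C/c2ccccc2Cl)c(=O)n1C`, 100 nM

In a functional assay on U-937 cells (Homo sapiens) for cytotoxicity, read by CCK-8 assay, with a stated time of 72 h (on this read-out lower numbers stand for stronger inhibition and higher numbers for weaker inhibition), compound 2 gives the highest of the three numbers: compound 1 and compound 3 each lie lower, beyond the scatter. Compound 4, `C=CCn1c(=O)/c(=C\c2ccccc2OC)[nH]c(=O)/c1=C\c1ccccc1OC`, has not yet been measured. It differs from compound 2 in one place: 2-methoxyphenyl in place of 5-fluoro-2-methylphenyl on a double-bonded chain carbon bound to an aromatic carbon. Among the measured compounds shown here, the only step measured between two compounds that differ in one place is no change at the digits printed from compound 1 to compound 3 (within the scatter), but that step concerns a chloro group on the other aromatic ring, not the group exchanged here, so it offers no direct guide. What the numbers do show is that compound 1 and compound 3, both carrying a 2-methoxyphenyl, give lower numbers than compound 2, though they also differ from compound 2 at the nitrogen substituent. A modest move toward lower numbers is therefore expected, a 2.5-fold lower number from compound 2 to compound 4 (0.40 log units; beyond the scatter), with wide uncertainty. Compound 4 is estimated at 400 nM, between 130 nM and 1300 nM.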

Compound 4, half-maximal inhibitory concentration: 5100 nM
Compound 4: middle estimate off by 13-fold (1.11 log units), on the low side; measured number outside the range, above it.
By their numbers in this assay, from the lowest: compounds 1 and 3 (each within the scatter of the next); then compound 2; then compound 4.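

In this assay, exchanging 5-fluoro-2-methylphenyl for 2-methoxyphenyl on a double-bonded chain carbon bound to an aromatic carbon gives a 5.1-fold higher number from compound 2 to compound 4 (0.71 log units; beyond the scatter), with the rest of the molecule unchanged. Among the compounds shown here, this is the first measured one-place change at this position, and it shows that the read-out responds to the group held there, even though both groups have the same count of 8 heavy atoms and one six-membered aromatic ring. No measured evidence here accounts for the step.

On these data alone, the exchange removes the fluorine and the methyl and brings in the methoxy all at once, so the share of each part in the step stays unknown. As far as these compounds go, it also remains open how this position would respond to a 2-aminophenyl or a 2-hydroxyphenyl group.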